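A few compounds are considered here, and "the series" means these few. Any claim that something is new, unique, unknown or untested is made for them only; others in the source may bear on it.

The measured compounds:
compound 1, `COc1cc(-c2cc(/C=C/C(=O)c3ccc(N)cc3)[nH]n2)cc(OC)c1OC` — in a functional assay on Hs-578T cells (Homo sapiens) for inhibition, read by sulforhodamine B assay, with a stated time of 48 h (a higher number here means a weaker inhibitor of growth, a lower number a stronger inhibitor of growth), compound 1 gives > 100000 nM, which is a limit of the assay rather than a number.
compound 2, `COc1ccc(-c2cc(/C=C/C(=O)c3ccc(OC)c(OC)c3)[nH]n2)cc1` — in this assay compound 2 gives 29000 nM.
compound 3, `COc1ccc(-c2cc(/C=C/C(=O)c3ccc(N)cc3)[nH]n2)cc1OC` — in this assay compound 3 gives > 100000 nM, again a limit of the assay and not a number.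

Compound 1 therefore stands only at a limit, and it shares that limit with compound 3, as the limit of > 100000 nM in this assay, at which 2 of the 3 values shown sit, shows; among the three values shown, only compound 2 gives a number. Among the compounds with values here, the one single-point step measured here, a step that the two limits leave unreadable from compound 1 to compound 3, runs between two limits and its size cannot be read.

Compound 4, `COc1ccc(C(=O)/C=C/c2cc(-c3cc(OC)c(OC)c(OC)c3)n[nH]2)cc1`, differs from compound 1 by methoxy in place of amino on an aromatic carbon. Within the data shown here, no measured step bears directly on this change. What the data do show is that both compounds carrying the amino group, compound 1 and compound 3, sit at the limit, while compound 2, whose ketone-side ring carries methoxy groups instead, gives a number. On that slender basis compound 4 is expected to come in at or somewhat below the limit, with the step from compound 1 to compound 4 estimated as an at least 2.0-fold lower number from compound 1 to compound 4 (0.30 log units; that floor lies within the scatter). The estimate for compound 4 in this assay is 50000 nM, within a range of 15000 nM to 150000 nM, with a real chance that only a limit is reported.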

Compound 4, concentration for total growth inhibition: > 100000 nM
Compound 4 was reported as a limit; the forecaster's own chance of this, stated with the estimate: 45%; middle value at least 2.0-fold (0.30 log units) away from the limit.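

In this assay compound 4 gives > 100000 nM which is a limit of the assay and not a number. Compound 1 also stands at a limit, so no step can be read between compound 1 and compound 4. The compounds shown leave open how large a step methoxy in place of amino on an aromatic carbon produces.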